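A Fluorinated Phenol Replaces the Methylsulfonyl Group

A few compounds are considered here, and "the series" means these few. Any claim that something is new, unique, unknown or untested is made for them only; others in the source may bear on it.

In a functional assay on A549 cells (Homo sapiens) for antiproliferative activity, read by MTT assay (a higher number here means a weaker inhibitor, a lower number a stronger inhibitor), compound 1 `Cn1c(=O)c(=O)n(C2CCCC2)c2nc(N/N=C/c3ccc(O)cc3)ncc21` gives > 100000 nM, which is a limit of the assay and not a number. Among the compounds with values here, compound 2 `Cn1c(=O)c(=O)n(C2CCCC2)c2nc(N/N=C/c3ccc(S(C)(=O)=O)cc3)ncc21` gives 84500 nM, the only actual number so far, and it stands close to the limit of > 100000 nM in this assay, at which 1 of the 2 values shown sits.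

Compound 3 `Cn1c(=O)c(=O)n(C2CCCC2)c2nc(N/N=C/c3ccc(O)c(F)c3)ncc21` carries 3-fluoro-4-hydroxyphenyl in place of 4-(methylsulfonyl)phenyl on a carbon with a double bond to nitrogen. Within the data shown here, one measured step bears on this change, the swap of hydroxy for methylsulfonyl taken in reverse: an at least 1.1-fold lower number from compound 1 to compound 2 (0.07 log units; that floor lies within the scatter). Among the measured compounds shown here, that step does not go beyond the scatter, and no measured step covers the added fluoro. In this assay, therefore, no change beyond the scatter is expected, and compound 3 could also end at the limit. The expected step is a 1.1-fold lower number from compound 2 to compound 3 (0.02 log units; within the scatter). Compound 3 is estimated at 80000 nM, with an expected range from 25000 nM to 200000 nM.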

Compound 3, half-maximal inhibitory concentration: 97800 nM
Compound 3: middle estimate off by 1.2-fold (0.09 log units), on the low side, and the stated range covers the measured number.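

In this assay, 3-fluoro-4-hydroxyphenyl in place of 4-(methylsulfonyl)phenyl gives a 1.2-fold higher number from compound 2 to compound 3 (0.06 log units; within the scatter), so this position now carries two actual numbers, and they cannot be told apart. Compound 1 gives > 100000 nM, which is a limit and not a number. Fluoro in place of hydrogen on an aromatic carbon therefore gives only a floor, an at least 1.0-fold lower number from compound 1 to compound 3 (0.00 log units; that floor lies within the scatter), which leaves the true size of that change unknown, and the three compounds all sit at or close to one boundary: the limit of > 100000 nM in this assay, at which 1 of the 3 values shown sits.

Going by these compounds, whether an amine or a carboxylic acid on this aromatic ring would bring the number well clear of that limit remains open. So does whether any change at this position can produce a step beyond the scatter.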